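The compounds below may be only part of what the source reports. "The series", "measured", "known", "first", "only" and "open" are said of these compounds alone.

Within the data shown here, in a functional assay on brain (Rattus norvegicus, strain Wistar) for inhibition (a higher number here means a weaker inhibitor, a lower number a stronger inhibitor), compound 3 `COc1ccc(-c2c(C)[nH]c(=O)n2C)cc1` gives 147000 nM, the highest number of the three measured so far. Compound 1 `CCCCc1ccc(-c2c(C)[nH]c(=O)n2C2CCCCC2)cc1` gives 27100 nM, and compound 2 `CCCCOc1ccc(-c2c(C)[nH]c(=O)n2C2CCCCC2)cc1` gives 13900 nM. Both carry butyl or butoxy chains, but they also differ from compound 3 elsewhere on the core. Compound 4 `CCCCCc1ccc(-c2c(C)[nH]c(=O)n2C)cc1` changes one place of compound 3: pentyl in place of methoxy on an aromatic carbon. Among the measured compounds shown here, the only measured single-place step, a 1.9-fold lower number from compound 1 to compound 2 (0.29 log units; within the scatter), stays within the scatter, so swapping butyl for butoxy tells little here. Only part of the gap between compound 3 and the other two can be expected to carry over. The expected change is a moderate drop, a 2.5-fold lower number from compound 3 to compound 4 (0.39 log units; beyond the scatter). For compound 4 the estimate is 60000 nM, with an expected range from 20000 nM to 180000 nM.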

Compound 4, half-maximal inhibitory concentration: 5900 nM
Estimate against measurement, compound 4: 10-fold (1.01 log units) above, outside the stated range (below it).
By their numbers in this assay, from the lowest: compound 4; then compounds 2 and 1 (each within the scatter of the next); then compound 3.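

In this assay, pentyl in place of methoxy gives a 25-fold lower number from compound 3 to compound 4 (1.40 log units; beyond the scatter), so the group on this aromatic carbon can shift the number strongly. The earlier swap of butyl for butoxy, a 1.9-fold lower number from compound 1 to compound 2 (0.29 log units; within the scatter), stayed within the scatter and gave no such sign. Nothing available explains the size of this step. This change lengthens the chain and removes the oxygen together, so the two effects cannot be told apart. A pentyloxy chain on the core of compound 3 would separate them, and an amine here would test a different kind of group.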